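This account rests on a few compounds, and the source may have more. Where it says the series, first, only, none or still open, it means among the compounds named here.

Numbers from an assay on FRT-Jurkat cells for inhibition of nuclear factor NF-kappa-B complex (Homo sapiens), read by flow cytometry, with a stated time of 24 h, tested at 10 uM (on this read-out lower numbers stand for less inhibition and higher numbers for more inhibition at the one concentration tested (going by the name of the read-out)), for the two measured compounds:

Compound 1 `O=C1CCC(N2C(=O)c3ccc(Nc4ccc(O)cc4)cc3C2=O)C(=O)N1`: 4%
Compound 2 `Cc1ccc(Nc2cccc3c2C(=O)N(C2CCC(=O)NC2=O)C3=O)cc1`: 9%

Both measured compounds sit low on this read-out. Compound 2 holds the larger of the two numbers, but the gap to compound 1 is within the usual scatter of repeated measurements, so the two cannot be ranked against each other and no change between them can be read. For the measured compounds named here, no step between measured compounds that differ in a single place is available, so the series gives no measured step to lean on.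

Compound 3 `CCc1ccc(Nc2cccc3c2C(=O)N(C2CCC(=O)NC2=O)C3=O)cc1` has not yet been measured in this assay. It differs from compound 2 by methyl in place of hydrogen on a saturated chain carbon bound to an aromatic carbon. Going by the values given here, nothing measured speaks to a change of this kind, and the two known numbers are near the floor of the read-out. The step from compound 2 is therefore expected to be a number 1 percentage points lower from compound 2 to compound 3 (within the scatter), that is, none beyond the scatter. For compound 3 in this assay the expected value is 8%, with a range from 0% to 20%.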

Compound 3, a percentage reported as inhibition, at one concentration (the size of the read-out at that concentration, not a potency): 17%
Beside the measured number, compound 3's estimate is 9 percentage points below it, and the stated range covers the measured number.
By their numbers in this assay, from the lowest: compounds 1, 2 and 3 (each within the scatter of the next, the first and the last beyond it).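

In this assay, for the compounds shown here, the exchange of 4-methylphenyl for 4-ethylphenyl gives a number 8 percentage points higher from compound 2 to compound 3 (within the scatter) and is the first measured step that differs in a single place. A methyl on this saturated chain carbon bound to an aromatic carbon therefore leaves the read-out inside the scatter of repeated measurements, so the change can be called neither a gain nor a loss on this single step. Nothing on hand bears on what lies behind the size of this step.

The compounds shown stop at ethyl, so it remains open whether a longer chain such as propyl, a branched chain such as isopropyl, or a chain ending in a hydroxyl or an amine would carry the read-out beyond the scatter. Going by these compounds alone, with only this one step, and with every number taken at a single concentration and so saying nothing of potency, it also remains open whether this assay responds to changes at this position at all.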